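The source may hold more compounds than are shown below. What is called first, only, known or untested is meant among the compounds shown, and "the series" means these compounds.

The compounds measured so far:
compound 1 `FC(F)(F)c1ccc(CSc2nc(Nc3cccc(Br)c3)c3ccccc3n2)cc1`, 23700 nM;
compound 2 `FC(F)(F)c1ccc(CSc2nc(Nc3ccc(C(F)(F)F)cc3)c3ccccc3n2)cc1`, 6170 nM.

Both numbers come from a functional assay on MGC-803 cells (Homo sapiens) for cytotoxicity, read by MTT assay, with a stated time of 72 h; on this read-out higher numbers stand for weaker inhibition and lower numbers for stronger inhibition. Among the compounds with values here, compound 2 holds the lowest of the two numbers; the only other measured compound, compound 1, lies higher, and the step of a 3.8-fold lower number from compound 1 to compound 2 (0.58 log units; beyond the scatter) is beyond the usual scatter. Within the data shown here, that step is the sole guide here: it shows that exchanging the aryl group on the ring nitrogen can move the read-out by a modest amount.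

Compound 3 `COc1cc(Nc2nc(SCc3ccc(C(F)(F)F)cc3)nc3ccccc23)cc(OC)c1` has not been measured. It differs from compound 2 in a single place: 3,5-dimethoxyphenyl in place of 4-(trifluoromethyl)phenyl on a nitrogen on an aromatic ring. Among the measured compounds shown here, the one measured step bears on this change only loosely, because it too, in a 3.8-fold lower number from compound 1 to compound 2 (0.58 log units; beyond the scatter), swapped one aryl group on that same nitrogen for another. Neither measured compound carries methoxy groups, so the direction of the present change cannot be read from the data. The step of a 1.9-fold higher number from compound 2 to compound 3 (0.29 log units; within the scatter) is therefore expected to be small, with a wide spread around it. Compound 3 is expected to give about 12000 nM in this assay, estimated to fall between 3000 nM and 45000 nM.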

Compound 3, half-maximal inhibitory concentration: 8580 nM
Compound 3: middle estimate off by 1.4-fold (0.15 log units), on the high side, and the stated range covers the measured number.
By their numbers in this assay, from the lowest: compounds 2 and 3 (each within the scatter of the next); then compound 1.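

In this assay, 3,5-dimethoxyphenyl in place of 4-(trifluoromethyl)phenyl on the nitrogen gives a 1.4-fold higher number from compound 2 to compound 3 (0.14 log units; within the scatter), so the read-out does not separate these two aryl groups, even though the entering group carries 2 hydrogen-bond acceptors and the leaving group 0. Set against the 3-bromophenyl of compound 1, the same dimethoxy group gives a 2.8-fold lower number from compound 1 to compound 3 (0.44 log units; beyond the scatter), which means that compound 1 now stands apart from two differently substituted aryl compounds rather than from one, and it holds the highest number of the three. Nothing available explains why these aryl groups give these numbers.

As far as these compounds go, the three compounds cover only substituted phenyl groups on this nitrogen, so it remains open whether a plain phenyl, a phenyl bearing an amine or a carboxylic acid, or a saturated chain such as butyl would lower the number further or raise it. The rest of the molecule is the same in all three, so these steps say nothing about changes made elsewhere on the shared core.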